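The source may hold more compounds than are shown below. What is called first, only, known or untested is meant among the compounds shown, and "the series" means these compounds.

Measured so far:
Compound 1 `O=C1[C@H]2[C@H](ON(c3ccccc3)[C@@H]2c2coc3ccc(F)cc3c2=O)C(=O)N1c1ccccc1` reaches only a limit of the assay in a functional assay on PC-3 cells (Homo sapiens) for inhibition, read by sulforhodamine B assay, with a stated time of 48 h (on this read-out lower numbers stand for stronger inhibition and higher numbers for weaker inhibition), > 60000 nM.
Compound 2 `Cc1ccc2occ([C@@H]3[C@H]4C(=O)N(c5ccccc5)C(=O)[C@H]4ON3c3ccccc3)c(=O)c2c1` gives 11100 nM.
Compound 3 `COC(=O)[C@@]1(C)C[C@@H](c2coc3ccc(F)cc3c2=O)N(c2ccccc2)O1` gives 31300 nM.

From compound 1 to compound 2 the change is methyl in place of fluoro on an aromatic carbon, and it brings an at least 5.4-fold lower number from compound 1 to compound 2 (0.73 log units; beyond the scatter); the size is bounded on one side only, since compound 1 sits at the limit of > 60000 nM in this assay, at which 1 of the 3 values shown sits. The difference between the core of compound 1 and the core of compound 3 is not broken down here. Compound 4 `COC(=O)[C@@]1(C)C[C@@H](c2coc3ccc(C)cc3c2=O)N(c2ccccc2)O1` is to be measured in this assay; it differs from compound 3 by methyl in place of fluoro on an aromatic carbon, the same change as from compound 1 to compound 2. The expected step is a 3.1-fold lower number from compound 3 to compound 4 (0.50 log units; beyond the scatter), resting on an at least 5.4-fold lower number from compound 1 to compound 2 (0.73 log units; beyond the scatter), though that earlier step is known only as a bound and the core differs. Compound 4 is therefore estimated at 10000 nM, between 3000 nM and 30000 nM.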

Compound 4, half-maximal inhibitory concentration: > 60000 nM
Compound 4 was reported as a limit; the forecaster's own chance of this, stated with the estimate: 5%; middle value at least 6.0-fold (0.77 log units) away from the limit.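

In this assay compound 4 gives > 60000 nM, which is a limit of the assay. Methyl in place of fluoro on an aromatic carbon brings an at least 1.9-fold higher number from compound 3 to compound 4 (0.28 log units; that floor lies within the scatter), whereas on the core of compound 1 the same change lowered the number, so the change does not carry over with the same result between these two cores: the same change on two cores in this assay, an at least 5.4-fold lower number (0.73 log units; beyond the scatter) from compound 1 to compound 2 and an at least 1.9-fold higher number (0.28 log units; that floor lies within the scatter) from compound 3 to compound 4, at least 10-fold (1.01 log units) apart, beyond the scatter of two such steps Both steps are known only as bounds, so their true sizes remain open, and two cores give no rule for the wider series: the limit of > 60000 nM in this assay, at which 2 of the 4 values shown sit.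

Open, as far as these compounds go, is whether chloro, methoxy or an amine on the same aromatic carbon would follow the core of compound 1 or the core of compound 3. Also open, from the compounds shown here alone, is how a carboxylic acid in place of the ester of compound 3 and compound 4 would read out in this assay.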